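Compound 3 to compound 4: series at the assay limit

A few compounds are considered here, and "the series" means these few. Any claim that something is new, unique, unknown or untested is made for them only; others in the source may bear on it.

In an ADME assay on HEK293 cells (Homo sapiens) for cytotoxicity, with a stated time of 72 h (on this read-out higher numbers stand for an effect only at larger amounts of compound and lower numbers for an effect already at smaller amounts), compound 1 (`Cc1cc(NC(=O)Nc2ccc(Cl)c(Cl)c2)c2ccccc2n1`) reads > 25000 nM as a limit of the assay. Compound 2 (`Cc1cc(NC(=O)Nc2cccnc2)c2ccccc2n1`) reads > 25000 nM as a limit too. Compound 3 (`Cc1cc(NC(=O)Nc2ccccc2F)c2ccccc2n1`) also reads > 25000 nM as a limit and has no number of its own. Going by the values given here, the one measured step is a step that the two limits leave unreadable from compound 2 to compound 3 and offers no size to carry forward. Compound 4 (`Cc1cc(NC(=O)Nc2cccc(Cl)c2)c2ccccc2n1`) has 3-chlorophenyl in place of 2-fluorophenyl on an amide-type nitrogen. Compound 4 is expected to show no step beyond the scatter in this assay because the limit of > 25000 nM in this assay, at which 3 of the 3 values shown sit, is all that compound 1, compound 2 and compound 3 show. The estimated change is a step that the limit leaves unreadable from compound 3 to compound 4 with no direction expected. For compound 4 the estimate is 30000 nM with an expected range of 15000 nM to 50000 nM and a limit of the assay remains the likeliest expected outcome.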

Compound 4, half-maximal effective concentration: 21000 nM
Beside the measured number, compound 4's estimate is 1.4-fold (0.15 log units) above it, within the range that was stated.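

In this assay compound 4 is the only compound shown with a number of its own, so 3-chlorophenyl on this amide-type nitrogen brings the series off the limit that holds the other compounds: the limit of > 25000 nM in this assay, at which 3 of the 4 values shown sit. Measured against those limits, the steps are an at least 1.1-fold lower number from compound 3 to compound 4 (0.07 log units; that floor lies within the scatter), an at least 1.1-fold lower number from compound 2 to compound 4 (0.07 log units; that floor lies within the scatter) and an at least 1.1-fold lower number from compound 1 to compound 4 (0.07 log units; that floor lies within the scatter). Each is only a floor, and none is shown to exceed the usual scatter.

On these data alone, whether an amine or a carboxylic acid in place of the 3-chlorophenyl would give a step beyond the scatter stays open.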